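The source may hold more compounds than are shown below. What is called first, only, known or untested is meant among the compounds shown, and "the series" means these compounds.

Measured compounds:
- compound 1, `O=C(CC1c2ccccc2N=C(SCCCCCN2CCCC2)N1c1ccc(-c2ccc(F)cc2)cc1)NCc1ccc(F)cc1`, gives 83.9% in an assay on cells for inhibition of Voltage-dependent T-type calcium channel subunit alpha-1G (Homo sapiens), read by patch clamp, tested at 10 uM; a lower number here means less inhibition, a higher number more inhibition at the concentration tested (going by the name of the read-out)
- compound 2, `CN(C)CCCCCSC1=Nc2ccccc2C(CC(=O)NCc2ccccc2)N1c1ccccc1`, gives 46.5% in this assay
- compound 3, `CN(C)CCCCCSC1=Nc2ccccc2C(CC(=O)NCc2ccc(F)cc2)N1c1ccc(-c2ccc(F)cc2)cc1`, gives 96.2% in this assay

Compound 2 stands lowest of the three measured numbers, beyond the scatter of both compound 1 and compound 3. The difference between the core of compound 2 and the core of compound 3 is not broken down here.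

Compound 1 and compound 3 differ in one place: pyrrolidin-1-yl in place of dimethylamino on a saturated chain carbon, five bonds along the chain from a sulfur. This change made the step of a number 12.3 percentage points lower from compound 3 to compound 1 (beyond the scatter).

Compound 4, `O=C(CC1c2ccccc2N=C(SCCCCCN2CCCC2)N1c1ccccc1)NCc1ccccc1`, has not yet been measured. It differs from compound 2 by pyrrolidin-1-yl in place of dimethylamino on a saturated chain carbon, five bonds along the chain from a sulfur, the same change at the same place, so it offers a second look at whether the change behaves alike on a different core.

From compound 2 to compound 4 the step is expected to be a number 10.5 percentage points lower from compound 2 to compound 4 (beyond the scatter) in this assay, resting on the step of a number 12.3 percentage points lower from compound 3 to compound 1 (beyond the scatter) seen once on the other core, though a single earlier instance leaves room for the step to differ in size. Compound 4 is therefore estimated at 36%, with the range 18% to 56%.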

Compound 4, a percentage reported as inhibition, at one concentration (the size of the read-out at that concentration, not a potency): 60.4%
Compound 4: the middle estimate sits 24.4 percentage points below what was measured, and the stated range ends below it.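

The new step is a number 13.9 percentage points higher from compound 2 to compound 4 (beyond the scatter), so on this core, pyrrolidin-1-yl in place of dimethylamino goes with more inhibition in this assay. Set beside the earlier step, the change does not carry over from one core to the other, even in direction: the same change on two cores in this assay, a number 12.3 percentage points lower (beyond the scatter) from compound 3 to compound 1 and a number 13.9 percentage points higher (beyond the scatter) from compound 2 to compound 4, 26.2 percentage points apart, beyond the scatter of two such steps This shows that, across these two pairs, the outcome of the change depends on the core it sits on, but it does not show which difference between the cores decides the direction, as those cores differ in more than one place.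

The compounds shown leave open whether another amine in the same place, such as piperidine or morpholine, would also behave differently on the two cores. They also leave open how the change would behave on a core that keeps the plain benzyl amide but carries the 4-fluorophenyl group, which could help to separate the two differences.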